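A few compounds are considered here, and "the series" means these few. Any claim that something is new, unique, unknown or untested is made for them only; others in the source may bear on it.

Compound 2, `Cc1ccc(-c2nc3ccc(F)cc3s2)cc1N`, has been tested in a functional assay on U-937 cells (Homo sapiens) for cytotoxicity, read by MTT assay, with a stated time of 2 days; a lower number here means a stronger inhibitor, a higher number a weaker inhibitor. In this assay compound 2 gives > 50000 nM, which is a limit of the assay rather than a measured number. Its closest measured relative is compound 1, `COc1ccc2nc(-c3ccc(C)c(N)c3)sc2c1`, which carries a methoxy where compound 2 carries a fluoro. In this assay compound 1 gives > 50000 nM, which is again a limit. Both results sit at the same edge of what this assay can report, as the limit of > 50000 nM in this assay, at which 2 of the 2 values shown sit, records, so the step that the two limits leave unreadable from compound 1 to compound 2 cannot be read for size or direction; all that is known is that neither compound reaches a measurable number. The unmeasured compound 3, `Cc1ccc(-c2nc3ccccc3s2)cc1N`, differs from compound 2 by a single change: hydrogen in place of fluoro on an aromatic carbon. Within the data shown here, no measured step in this small set bears on exchanging fluoro for hydrogen, and the one step that exists is itself unreadable. The expectation for compound 3 is therefore that it will most likely also sit at the limit of this assay, with an estimated step that the limit leaves unreadable from compound 2 to compound 3 amounting to nothing beyond the scatter. Compound 3 is estimated at 80000 nM in this assay, within a range from 25000 nM to 300000 nM.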

Compound 3, half-maximal inhibitory concentration: > 50000 nM
Compound 3 was reported as a limit (the forecaster's own chance of this, stated with the estimate: 85%); the middle value does not contradict the limit.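

Compound 3, like compound 1 and compound 2, is reported only as a limit in this assay, so no new step among these compounds can be read for size or direction: the limit of > 50000 nM in this assay, at which 3 of the 3 values shown sit. From the compounds shown here alone, whether methoxy, fluoro or hydrogen on this aromatic carbon makes any difference to cytotoxicity remains open.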